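The compounds below may be only part of what the source reports. "The series", "measured", "known", "first", "only" and "open" are said of these compounds alone.

Going by the values given here, in an ADME assay, at pH 5 (on this read-out lower numbers stand for a shorter-lived compound and higher numbers for a longer-lived compound), compound 1 (`COc1cnc(C[S+]([O-])c2nc3cc(OC(F)F)ccc3[nH]2)cc1OC`) gives 2.1 h as its half-life, and compound 2 (`COc1cnc(C[S+]([O-])c2nc3cc(OC(F)F)ccc3[nH]2)c(C)c1OC`) gives 3.7 h as its own, so compound 1 stands within the scatter of the one other number available. Compound 3 (`COc1ccnc(C[S+]([O-])c2nc3cc(OC(F)F)ccc3[nH]2)c1`) awaits measurement in this assay and differs from compound 1 (hydrogen in place of methoxy on an aromatic carbon) by hydrogen in place of methoxy on an aromatic carbon, ortho to a methoxy group and two atoms from the ring nitrogen. Among the compounds with values here, only one measured step is at hand, a 1.8-fold higher number from compound 1 to compound 2 (0.25 log units; within the scatter) for methyl in place of hydrogen on an aromatic carbon, and it bears only loosely, since it is a different exchange and stays within the scatter. Within the data shown here, no measured pair loses a methoxy, so the direction remains open and no shift beyond the scatter is expected. The expected step is a 1.1-fold lower number from compound 1 to compound 3 (0.04 log units; within the scatter) as an estimate, with the range kept wide. For compound 3 the estimated half-life is 1.9 h with 1 h to 3.6 h as the expected range.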

Compound 3, half-life: 0.8 h
Compound 3: middle estimate off by 2.4-fold (0.38 log units), on the high side; the whole stated range lies above it.
By their numbers in this assay, from the lowest: compound 3; then compounds 1 and 2 (each within the scatter of the next).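

In this assay, the methoxy group on this aromatic carbon, ortho to a methoxy group and two atoms from the ring nitrogen, proves to matter: exchanging it for hydrogen gives a 2.6-fold lower number from compound 1 to compound 3 (0.42 log units; beyond the scatter) in the only step shown that clears the scatter, although the step is modest. Going by these compounds alone, the other step, a 1.8-fold higher number from compound 1 to compound 2 (0.25 log units; within the scatter) for methyl in place of hydrogen on an aromatic carbon, gave no such reading, so this exchange is the first to show that a single change on this ring can move the half-life measurably, with the shorter half-life belonging to the compound without this methoxy group. Nothing available explains why the half-life falls with this exchange.

The compounds shown leave open whether the oxygen or the methyl of the methoxy group carries this difference, and whether a hydroxyl, an ethoxy group, a chlorine atom or a dimethylamino group on the same carbon would behave like methoxy or like hydrogen. They also leave open whether the same exchange would shift the half-life by a similar amount in the presence of the added methyl of compound 2.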